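This account rests on a few compounds, and the source may have more. Where it says the series, first, only, none or still open, it means among the compounds named here.

In a functional assay on cells for positive allosteric modulation of metabotropic glutamate receptor 2 (Homo sapiens), read by fluorescence and calcium flux, with a stated time of 30 min (on this read-out higher numbers stand for an effect only at larger amounts of compound and lower numbers for an effect already at smaller amounts), compound 1 `Fc1cc(Cl)ccc1-c1ccc(Cn2nnc3c(C(F)(F)F)cccc32)cn1` gives 13 nM. Compound 2 `Fc1cc(Cl)ccc1-c1ccc(Cn2nnc3c(Br)cccc32)cn1` differs from compound 1 by one change, (bromo in place of trifluoromethyl on an aromatic carbon), and in this assay compound 2 gives 6 nM. That change made a step of a 2.2-fold lower number from compound 1 to compound 2 (0.34 log units; beyond the scatter). Compound 3 `FC(F)(F)c1cc(Br)c2nnn(CC3CC3)c2c1` is built on another core; the difference between the core of compound 3 and the core of compound 1 is not broken down here. In this assay compound 3 gives 140 nM, the highest of the three numbers. Compound 4 `Brc1cc(Br)c2nnn(CC3CC3)c2c1` has not been measured. It differs from compound 3 by bromo in place of trifluoromethyl on an aromatic carbon. Going by the values given here, this is the same kind of change as the one from compound 1 to compound 2, but not the same: in compound 4 the bromo sits meta to a bromo group, meta to a fused ring and para to a fused ring, whereas in compound 2 it sits ortho to a fused ring and meta to a fused ring. Among the compounds with values here, the earlier step of a 2.2-fold lower number from compound 1 to compound 2 (0.34 log units; beyond the scatter) is the only guide, and the core and the surroundings of the changed place both differ, so it is only a rough one. For compound 4 a somewhat smaller step toward lower numbers is expected, a 1.8-fold lower number from compound 3 to compound 4 (0.24 log units; within the scatter). In this assay compound 4 is estimated at 80 nM, with a likely range from 35 nM to 200 nM.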

Compound 4, half-maximal effective concentration: 50 nM
Beside the measured number, compound 4's estimate is 1.6-fold (0.20 log units) above it; low and high end bracket the measured number.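

In this assay, putting bromo in place of trifluoromethyl gave a 2.8-fold lower number from compound 3 to compound 4 (0.45 log units; beyond the scatter), so the same swap again moved the number down on a second core. Set beside the earlier step, the two results agree in direction and, as far as the scatter allows, in size: the same change on two cores in this assay, a 2.2-fold lower number (0.34 log units; beyond the scatter) from compound 1 to compound 2 and a 2.8-fold lower number (0.45 log units; beyond the scatter) from compound 3 to compound 4, 1.3-fold (0.11 log units) apart, within the scatter of two such steps

This shows that, for these two pairs, the effect of the swap carried over from one core to the other, even though the core and the surroundings of the changed place both differ, but two pairs cannot show that it would hold on any further core, and they do not explain why the number falls. The compounds shown have only trifluoromethyl or bromo at this place, so it remains open how a chloro group, a nitrile or a methoxy group would read there. Also open, going by these compounds, is whether the step would keep its size if an amine or a carboxylic acid were added elsewhere on the molecule.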